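From Fluoro to Chloro on the Triazole Aryl Ring

The source may report more compounds than this note shows. Statements on the series, on what has been measured and on what is new or still open speak of the compounds shown alone.

Of the compounds shown here, three of a shared core have been tested in a functional assay on HepG2 cells (Homo sapiens) for antiproliferative activity, read by MTT assay, with a stated time of 72 h; a higher number here means a weaker inhibitor, a lower number a stronger inhibitor. Compound 1 `O=c1nc2oc(C3CC3)c(C#CC3CC3)c2cn1Cc1cn(-c2ccccc2F)nn1` gives 39100 nM in this assay. Compound 2 `CCCCCc1ccc(C#Cc2c(-c3ccc(CCCCC)cc3)oc3nc(=O)n(Cc4cn(-c5ccccc5F)nn4)cc23)cc1`, which carries two pentylphenyl groups on its core, gives 72500 nM. For compound 3 `CCCCCCC#Cc1c(CCCCCC)oc2nc(=O)n(Cc3cn(-c4ccc(F)cc4)nn3)cc12` the assay reports only a limit, > 100000 nM, and not a number. This places compound 3 at the limit of > 100000 nM in this assay, at which 1 of the 3 values shown sits, so its position relative to compound 1 and compound 2 cannot be set more precisely than that.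

Compound 4 `CCCCCCC#Cc1c(CCCCCC)oc2nc(=O)n(Cc3cn(-c4ccc(Cl)cc4)nn3)cc12` is the next member. It differs from compound 3 by chloro in place of fluoro on an aromatic carbon. Within the data shown here, no measured pair shows the effect of such a swap on this core, so there is no step to lean on. Given that compound 3 sits at > 100000 nM, compound 4 is expected to remain near that limit, with no step beyond the scatter, and the estimated step of a number no higher from compound 3 to compound 4 (the limit leaves the size open) reflects this. The estimate for compound 4 is 100000 nM, within 40000 nM to 300000 nM.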

Compound 4, half-maximal inhibitory concentration: > 100000 nM
Compound 4 gave a limit, no number; the forecaster's own chance of this, stated with the estimate: 70%; the middle value sits exactly at the limit.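

Among these compounds, compound 3 and compound 4 both give a limit of the assay and not a number, so no step between them can be read: the limit of > 100000 nM in this assay, at which 2 of the 4 values shown sit.

The compounds shown leave open whether 4-chlorophenyl in place of 4-fluorophenyl changes antiproliferative activity on the shared core.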